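This account rests on a few compounds, and the source may have more. Where it says the series, first, only, none or still open, it means among the compounds named here.

Of the compounds shown here, three have numbers so far. In an ADME assay on the whole organism (Mus musculus, strain CD1) for pharmacokinetics, at a dose of 2 mg/kg by the intravenous route (on this read-out higher numbers stand for fast clearance and lower numbers for slow clearance), compound 1 (`COc1cc(N2C(=O)C3(CCC3)N(c3ccc(OC4CCN(C)CC4)nc3)C2=S)cnc1C#N`) gives 8.8 mL/min/kg and compound 2 (`CN1CCC(Oc2ccc(N3C(=S)N(c4cnc(C#N)c(C(F)(F)F)c4)C(=O)C34CCC4)cc2)CC1`) gives 4.12 mL/min/kg while compound 3 (`Cc1cc(N2C(=O)C3(CCC3)N(c3ccc(OC4CCNCC4)nc3)C2=S)cnc1C#N`) gives 19.4 mL/min/kg as the top value. Compound 2 is the lowest of the three, and its gaps to compound 1 and to compound 3 both lie beyond the scatter.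

The next step leads to compound 4 (`N#Cc1ncc(N2C(=O)C3(CCC3)N(c3ccc(CN4CCNCC4)cc3)C2=S)cc1C(F)(F)F`), which carries (piperazin-1-yl)methyl in place of (1-methylpiperidin-4-yl)oxy on an aromatic carbon. Within the data shown here, no measured pair differs in one place only, so this step has no direct precedent. The closest guide is compound 3 (at 19.4 mL/min/kg), which like compound 4 has a hydrogen-bond donor in its amine ring, though it also differs from compound 4 elsewhere. An increase beyond the scatter is expected, estimated as a 3.4-fold higher number from compound 2 to compound 4 (0.53 log units; beyond the scatter) on this read-out. Compound 4 is estimated at 14 mL/min/kg with an expected range from 6 mL/min/kg to 32 mL/min/kg in this measurement.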

Compound 4, clearance: 18.2 mL/min/kg
Beside the measured number, compound 4's estimate is 1.3-fold (0.11 log units) below it; measured number inside the range.
By their numbers in this assay, from the lowest: compound 2; then compound 1; then compounds 4 and 3 (each within the scatter of the next).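

In this assay, among these compounds, a 4.4-fold higher number from compound 2 to compound 4 (0.65 log units; beyond the scatter) gives the series its first comparison in which only one place changes, and it shows that clearance responds to the group on this aromatic carbon, para to a large group. The change is composite: the oxygen leaves, the ring gains a second hetero atom, and a hydrogen-bond donor enters, and this single step cannot separate these parts. No measurement shown here bears on why the number rises.

The compounds shown leave open which of these parts carries the step; (4-methylpiperazin-1-yl)methyl on the same carbon, which has no ring hydrogen-bond donor, would test the donor on its own. Also open, from the compounds shown here alone, is whether a step of this size would recur with the other substituents seen on the cores of compound 1 and compound 3.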